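Notes on the aryl exchange from compound 2 to compound 3

A few compounds are considered here, and "the series" means these few. Any claim that something is new, unique, unknown or untested is made for them only; others in the source may bear on it.

Measured so far in a functional assay on MCF7 cells (Homo sapiens) for antiproliferative activity, read by MTT assay; a higher number here means a weaker inhibitor, a lower number a stronger inhibitor:
compound 1 `COc1ccc(-c2cc(CN(c3nc4ccc(F)cc4s3)c3nc4ccc(OC)cc4s3)on2)cc1` gives 32400 nM.
compound 2 `COc1ccc2nc(N(Cc3cc(-c4cc(OC)c(OC)c(OC)c4)no3)c3nc4ccc(F)cc4s3)sc2c1` gives 26600 nM.

Among the compounds with values here, compound 2 stands at the lowest of the two numbers, with compound 1 as its only neighbour, and the two lie within the scatter of each other, so no order between them is claimed. Within the data shown here, the one measured step, a 1.2-fold lower number from compound 1 to compound 2 (0.09 log units; within the scatter), exchanges the aryl group on the shared core and leaves the read-out essentially unchanged.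

Compound 3 `COc1ccc2nc(N(Cc3cc(-c4ccccc4F)no3)c3nc4ccc(F)cc4s3)sc2c1` carries a further exchange at the same position: 2-fluorophenyl in place of 3,4,5-trimethoxyphenyl on an aromatic carbon. The step from compound 1 to compound 2 is the only one that bears on it, since it alters the same aryl group, and it showed no movement beyond the scatter. Among the measured compounds shown here, the incoming group lacks the acceptors of the outgoing one, but no measured step tests this. The expectation for compound 3 is therefore a step of about a 1.1-fold higher number from compound 2 to compound 3 (0.05 log units; within the scatter) in this assay, not beyond the scatter. Compound 3 is estimated at 30000 nM, with a range from 12000 nM to 75000 nM.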

Compound 3, half-maximal inhibitory concentration: 28500 nM
Estimate against measurement, compound 3: 1.1-fold (0.02 log units) above, within the range that was stated.
By their numbers in this assay, from the lowest: compounds 2, 3 and 1 (each within the scatter of the next).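

In this assay, 2-fluorophenyl in place of 3,4,5-trimethoxyphenyl gives a 1.1-fold higher number from compound 2 to compound 3 (0.03 log units; within the scatter), and 2-fluorophenyl in place of 4-methoxyphenyl gives a 1.1-fold lower number from compound 1 to compound 3 (0.06 log units; within the scatter), so all three aryl groups on this carbon of the five-membered aromatic ring lie within the scatter of one another. The position therefore now tolerates more than a change in the number of methoxy groups: the read-out stays level when 3,4,5-trimethoxyphenyl, with 12 heavy atoms and 3 hydrogen-bond acceptors, gives way to a fluorine-bearing ring with 7 heavy atoms and 0 hydrogen-bond acceptors. No independent data explain this flat result.

From the compounds shown here alone, all three groups are substituted phenyl rings, so it remains open whether an amine or a carboxylic acid on that ring, or a longer chain in place of the ring, would shift the number beyond the scatter. The rest of the shared core is the same throughout, which leaves open how much of the read-out depends on it.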